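Selenium Sugar Nucleosides: Swapping Azido for Hydroxy

The source may report more compounds than this note shows. Statements on the series, on what has been measured and on what is new or still open speak of the compounds shown alone.

compound 1 `[N-]=[N+]=N[C@@H]1C(n2ccc(=O)[nH]c2=O)[Se][C@H](CO)[C@H]1O` — > 100000 nM
compound 2 `[N-]=[N+]=N[C@@H]1C(n2cc(Cl)c(=O)[nH]c2=O)[Se][C@H](CO)[C@H]1O` — > 100000 nM
compound 3 `[N-]=[N+]=N[C@@H]1C(n2cc(I)c(=O)[nH]c2=O)[Se][C@H](CO)[C@H]1O` — > 100000 nM

In a functional assay on A549 cells (Homo sapiens) for cytotoxicity, read by sulforhodamine B assay (a higher number here means a weaker inhibitor, a lower number a stronger inhibitor), compound 1 reaches only the limit of the assay, > 100000 nM. Compound 2 likewise stops at a limit, > 100000 nM. Compound 3 also gives a limit, > 100000 nM. The steps a step that the two limits leave unreadable from compound 1 to compound 2, a step that the two limits leave unreadable from compound 1 to compound 3 and a step that the two limits leave unreadable from compound 2 to compound 3 stay unreadable, since all three values sit at the limit of > 100000 nM in this assay, at which 3 of the 3 values shown sit. Compound 4 `O=c1ccn(C2[Se][C@H](CO)[C@@H](O)[C@@H]2O)c(=O)[nH]1` differs from compound 1 by hydroxy in place of azido on a saturated ring carbon. Among the measured compounds shown here, no measured step touches this position, and every measured compound sits at the limit, so the expectation for compound 4 is again no measurable inhibition. The expected step is a step that the limit leaves unreadable from compound 1 to compound 4, of no readable size. Compound 4 is estimated at 150000 nM, within a range from 50000 nM to 500000 nM.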

Compound 4, half-maximal inhibitory concentration: > 100000 nM
Compound 4 ended at the assay's limit; the forecaster's own chance of this, stated with the estimate: 85%; the middle value lies beyond the limit too.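

Compound 1 and compound 4 both stop at a limit, so hydroxy in place of azido gives no readable step: the limit of > 100000 nM in this assay, at which 4 of the 4 values shown sit. The compounds shown leave open what inhibition, if any, this shared core can reach in this assay.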